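Hydroxypropyl and acetoxypropyl analogues on two cores

The source may report more compounds than this note shows. Statements on the series, on what has been measured and on what is new or still open speak of the compounds shown alone.

Measured compounds:
compound 1, `CC(=O)OCCCc1cnc2ncnn2c1`: 45%
compound 2, `CCn1ncc2cc(CCCOC(C)=O)cnc21`: 16%
compound 3, `OCCCc1cnc2ncnn2c1`: 43%

The read-out throughout is a functional assay on THP-1 cells (Homo sapiens) for inhibition, read by ELISA, tested at 10 uM; a higher number here means more inhibition at the concentration tested (going by the name of the read-out), a lower number less inhibition. Compound 1 and compound 3 share one core and differ only at the side-chain end: hydrogen in place of acetyl on an oxygen on a saturated carbon. This change gave a number 2 percentage points lower from compound 1 to compound 3 (within the scatter), so on this core the acetyl and the free hydroxyl end are not told apart by the measurement.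

Compound 2 carries a different core and the acetyl end; in this assay compound 2 sits lowest of the three measured numbers, with compound 3 and compound 1 both beyond the scatter above it. The difference between the two cores is not broken down here.

Compound 4, `CCn1ncc2cc(CCCO)cnc21`, is not yet measured. It stands to compound 2 as compound 3 stands to compound 1: hydrogen in place of acetyl on an oxygen on a saturated carbon. The place of the change is described in the same words for both pairs, so this is the same change, made on the second core.

Among the compounds with values here, the one precedent for this change, from compound 1 to compound 3, moved the number by less than the scatter. Within the data shown here, on that basis the step from compound 2 to compound 4 is expected to be small as well, a number 1 percentage points lower from compound 2 to compound 4 (within the scatter), with the caveat that the second core has only one measured member. Compound 4 is therefore estimated at 15%, in the range from 4% to 28%.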

Compound 4, a percentage reported as inhibition, at one concentration (the size of the read-out at that concentration, not a potency): 45%
The estimate for compound 4 lay 30 percentage points below the measured number; the whole stated range lies below it.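

In this assay, the change from acetoxy to hydroxy on the second core gave a number 29 percentage points higher from compound 2 to compound 4 (beyond the scatter), so the outcome on the core of compound 1 does not carry over to the core of compound 2: the same change on two cores in this assay, a number 2 percentage points lower (within the scatter) from compound 1 to compound 3 and a number 29 percentage points higher (beyond the scatter) from compound 2 to compound 4, 31 percentage points apart, beyond the scatter of two such steps

For these two pairs, then, the size of the step depends on the core that carries it, and a near-silent step on one core is no safe basis for estimating the same step on another. This does not show why the two cores part here, whether either step would look the same across a range of concentrations, or how the change would behave on any third core, since each core contributes a single pair and each number is a percentage at one concentration rather than a potency.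

The compounds shown leave open whether the core dependence is specific to the acetyl and hydroxy pair or also appears with other ends on the side chain, such as an amine or a carboxylic acid in place of the hydroxy. They also leave open what a longer chain carrying the same hydroxy would do on each core.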